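Cyclohexyl for Isopropyl in Cathepsin S Nitrile Inhibitors

The compounds below may be only part of what the source reports. "The series", "measured", "known", "first", "only" and "open" are said of these compounds alone.

Measured so far in an assay for inhibition of cathepsin S (Homo sapiens); a higher number here means a weaker inhibitor, a lower number a stronger inhibitor:
- compound 1 `CC(C)C[C@H](NC(=O)N1CCOCC1)C(=O)NC(C)(C)C#N` gives 114 nM
- compound 2 `Cc1ccccc1COC[C@@H](C#N)NC(=O)[C@H](CC(C)C)NC(=O)N1CCOCC1` gives 19 nM
- compound 3 `Cc1ccccc1COC[C@@H](C#N)NC(=O)[C@H](CC1CCCCC1)NC(=O)N1CCOCC1` gives 7 nM

Compound 1 has the highest number of the three. Compound 2 and compound 3 share a core that differs from the core of compound 1, and that difference between the two cores is not broken down here. Between compound 2 and compound 3 the change is cyclohexyl in place of isopropyl on a saturated chain carbon, two bonds along the chain from an amide-type nitrogen and a carbonyl carbon, and it brought a 2.7-fold lower number from compound 2 to compound 3 (0.43 log units; beyond the scatter).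

Compound 4 `CC(C)(C#N)NC(=O)[C@H](CC1CCCCC1)NC(=O)N1CCOCC1` is not yet measured. Among the measured compounds shown here, it differs from compound 1 by cyclohexyl in place of isopropyl on a saturated chain carbon, two bonds along the chain from an amide-type nitrogen and a carbonyl carbon, the same change as the one from compound 2 to compound 3, at the same place. If the step repeats on the core of compound 1, compound 4 is expected to show a 2.7-fold lower number from compound 1 to compound 4 (0.43 log units; beyond the scatter), resting on a 2.7-fold lower number from compound 2 to compound 3 (0.43 log units; beyond the scatter). The estimate for compound 4 in this assay is therefore 42 nM, expected between 18 nM and 100 nM.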

Compound 4, half-maximal inhibitory concentration: 17 nM
For compound 4 the middle estimate is 2.5-fold (0.39 log units) above the measured one, outside the stated range (below it).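

In this assay cyclohexyl in place of isopropyl gives a 6.7-fold lower number from compound 1 to compound 4 (0.83 log units; beyond the scatter) on a second core, so the number falls on both cores shown. The two steps point the same way, and the gap in their sizes is no larger than repeat measurements could produce: the same change on two cores in this assay, a 2.7-fold lower number (0.43 log units; beyond the scatter) from compound 2 to compound 3 and a 6.7-fold lower number (0.83 log units; beyond the scatter) from compound 1 to compound 4, 2.5-fold (0.39 log units) apart, within the scatter of two such steps. Among the compounds shown here, this supports carrying the change between these two cores, but with only one pair on each core, it does not show that the change would hold on a third core or why the number falls.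

The compounds shown leave open what other groups would do at this place on either core, such as a phenyl ring or a longer chain.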